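The source may hold more compounds than are shown below. What is called first, only, known or untested is meant among the compounds shown, and "the series" means these compounds.

Compound 1 `COc1ccc(CNC(=O)/C(C#N)=C/c2ccc[nH]2)cc1`: > 50000 nM
Compound 2 `COc1ccc(CNC(=O)/C(C#N)=C/c2ccc(Cl)o2)cc1`: 13000 nM

In a functional assay on SJ-G2 cells (Homo sapiens) for inhibition, read by MTT assay, with a stated time of 72 h (on this read-out higher numbers stand for weaker inhibition of growth and lower numbers for stronger inhibition of growth), compound 1 gives > 50000 nM, which is a limit of the assay rather than a number. Compound 2 gives 13000 nM, the only number shown. Compound 3 `COc1ccc(CNC(=O)/C(C#N)=C/c2ccc(Br)o2)cc1` differs from compound 2 by bromo in place of chloro on an aromatic carbon. For the measured compounds named here, the single measured step, an at least 3.8-fold lower number from compound 1 to compound 2 (0.58 log units; beyond the scatter), exchanges one whole ring for another, so no measured step bears directly on a swap of one halogen for another. The step of a 1.3-fold lower number from compound 2 to compound 3 (0.11 log units; within the scatter) is therefore expected to stay within the scatter. The estimate for compound 3 is 10000 nM, with a range from 3500 nM to 30000 nM.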

Compound 3, concentration for 50% growth inhibition: 13000 nM
For compound 3 the middle estimate is 1.3-fold (0.11 log units) below the measured one; measured number inside the range.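

In this assay, the carbon next to the ring oxygen now carries a second halogen, and the swap gives no change at the digits printed from compound 2 to compound 3 (within the scatter), so chloro and bromo cannot be told apart here. With bromo, the change from the pyrrole compound gives an at least 3.8-fold lower number from compound 1 to compound 3 (0.58 log units; beyond the scatter), so this gap is seen with both halogens. The size of that gap has no upper end, as compound 1 gives a limit and not a number: the limit of > 50000 nM in this assay, at which 1 of the 3 values shown sits.

Ring and halogen change together in that step, so their separate shares stay open. So does the effect of a methyl or an amine on this carbon.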